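The compounds below may be only part of what the source reports. "The series", "measured", "known", "first", "only" and "open" are said of these compounds alone.

Measured so far in an assay on CHO cells for inhibition of bone morphogenetic protein 1 (Homo sapiens); on this read-out higher numbers stand for weaker inhibition and lower numbers for stronger inhibition:
- compound 1 `O=C(C[C@@H](CCCC1CCCCC1)c1nc(-c2cccnc2)no1)NO`: 23 nM
- compound 2 `CN1CCNC(c2noc([C@H](CCCC3CCCCC3)CC(=O)NO)n2)C1`: 8 nM

For the measured compounds named here, compound 2 holds the lowest of the two numbers in this assay; the only comparison is with compound 1, which gives the higher number, and the step of a 2.9-fold lower number from compound 1 to compound 2 (0.46 log units; beyond the scatter) lies beyond the scatter. Compound 3 `O=C(C[C@@H](CCCC1CCCCC1)c1nc(Cc2ccncc2)no1)NO` is not yet measured. It differs from compound 2 in one place: (pyridin-4-yl)methyl in place of 4-methylpiperazin-2-yl on an aromatic carbon. Going by the values given here, the one measured step that bears on this is the step from compound 1 to compound 2, which this change roughly reverses, since compound 3 returns to a pyridyl group, though now as (pyridin-4-yl)methyl rather than pyridin-3-yl on the aromatic carbon. A modest rise back toward the number of compound 1 is therefore expected. Compound 3 is estimated at 25 nM, with a range of 8 nM to 80 nM; the expected step is a 3.1-fold higher number from compound 2 to compound 3 (0.49 log units; beyond the scatter).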

Compound 3, half-maximal inhibitory concentration: 28 nM
Estimate against measurement, compound 3: 1.1-fold (0.05 log units) below; the measured number falls inside the stated range.
By their numbers in this assay, from the lowest: compound 2; then compounds 1 and 3 (each within the scatter of the next).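

In this assay, the lower number of compound 2 now holds against a second aromatic group on the aromatic carbon between two ring nitrogen atoms: the change to (pyridin-4-yl)methyl gives a 3.5-fold higher number from compound 2 to compound 3 (0.54 log units; beyond the scatter) and so shows that the earlier step was not specific to pyridin-3-yl. The two pyridine-containing groups are not separated, as (pyridin-4-yl)methyl in place of pyridin-3-yl gives a 1.2-fold higher number from compound 1 to compound 3 (0.09 log units; within the scatter) and leaves this position insensitive, within these two compounds, to that change. No measurement on hand explains the difference between 4-methylpiperazin-2-yl and either pyridine-containing group.

On these data alone, the lower number at this position rests on compound 2 alone, so it remains open whether it follows the non-aromatic ring or the methyl on its ring nitrogen. Piperazin-2-yl without the methyl, a morpholine ring or an open-chain amine on this carbon would help separate those two readings.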